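A New Amide Partner for Compound 2

A few compounds are considered here, and "the series" means these few. Any claim that something is new, unique, unknown or untested is made for them only; others in the source may bear on it.

Compound 1, `COc1cc(C(=O)N2CCC(O)C(C)C2)cc2nc(NCc3cc(Cl)ccn3)oc12`, gives 190 nM in an assay on isolated protein for inhibition of thyroid hormone receptor beta (Homo sapiens), read by fluorescence, with a stated time of 30 min; on this read-out higher numbers stand for weaker inhibition and lower numbers for stronger inhibition.
Compound 2, `COc1cc(C(=O)N2CCC(O)C(C)C2)cc2nc(N[C@H](C)c3cccc(Cl)c3)oc12`, gives 48 nM in this assay.
Compound 3, `COc1cc(C(=O)N2CCC(O)C(C)C2)cc2nc(NC3(c4cccc(Cl)c4)CCC3)oc12`, gives 8200 nM in this assay.

Among these three, compound 2 has the lowest number, which on this read-out means the strongest inhibition. Two steps separate it from the other two: a 4.0-fold lower number from compound 1 to compound 2 (0.60 log units; beyond the scatter) and a 170-fold higher number from compound 2 to compound 3 (2.23 log units; beyond the scatter); the step of a 43-fold higher number from compound 1 to compound 3 (1.64 log units; beyond the scatter) completes the set. All three measured steps change the group attached to the nitrogen on the aromatic ring, and they show that this part of the molecule can move the number a great deal.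

Compound 4, `COc1cc(C(=O)N2CC(C)(CCO)OC[C@H]2C)cc2nc(N[C@H](C)c3cccc(Cl)c3)oc12`, keeps that nitrogen substituent of compound 2 untouched and instead alters the other end of the shared core: 2-(2-hydroxyethyl)-2,5-dimethylmorpholin-4-yl in place of 4-hydroxy-3-methylpiperidin-1-yl on a carbonyl carbon. Among the compounds with values here, none of the measured steps alters this amide part, so the data give no direct guide to its effect. With nothing to point either way, the most reasonable expectation is a number close to that of compound 2, with wide uncertainty. The expected step is a 1.5-fold higher number from compound 2 to compound 4 (0.16 log units; within the scatter). Compound 4 is thus estimated at 70 nM, with a plausible range from 20 nM to 250 nM.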

Compound 4, half-maximal inhibitory concentration: 0.5 nM
For compound 4 the middle estimate is 140-fold (2.15 log units) above the measured one; the whole stated range lies above it.
By their numbers in this assay, from the lowest: compound 4; then compound 2; then compound 1; then compound 3.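

The earlier compounds shown here varied only the group on the nitrogen, so they said nothing about the amide end of the molecule. In this assay, the step of a 96-fold lower number from compound 2 to compound 4 (1.98 log units; beyond the scatter) shows that the group on the carbonyl carbon can also move the number by a large amount, and here the change runs towards stronger inhibition, with the nitrogen substituent left as it was. This single swap changes several things at once: 2-(2-hydroxyethyl)-2,5-dimethylmorpholin-4-yl has 2 hetero atoms in its ring where 4-hydroxy-3-methylpiperidin-1-yl has 1, and it also differs in its carbon substituents and has a defined stereocentre, while no measurement given here accounts for the gain.

The compounds shown cannot tell which of these differences matters, and a version carrying an ethyl or 2-aminoethyl group in place of the 2-hydroxyethyl group would test the role of that chain's hydroxyl. As far as these compounds go, it also remains open whether the new amide partner would give a similar gain with another nitrogen substituent, such as the (4-chloropyridin-2-yl)methyl group of compound 1.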